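From methylamino to phenyl at the assay limit

The source may report more compounds than this note shows. Statements on the series, on what has been measured and on what is new or still open speak of the compounds shown alone.

Measured in a functional assay on HeLa cells (Homo sapiens), read by colorimetric assay, with a stated time of 48 h; on this read-out lower numbers stand for stronger inhibition and higher numbers for weaker inhibition:
- compound 1 `OC[C@@H](O)[C@H]1O[C@@H](n2cnc3c(Cl)ncnc32)[C@H](O)[C@@H]1O`: > 100000 nM, a limit
- compound 2 `CNc1ncnc2c1ncn2[C@@H]1O[C@H]([C@H](O)CO)[C@@H](O)[C@H]1O`: > 100000 nM, a limit

Compound 2 stands at > 100000 nM in this assay, which is a limit and not a number. Both measured compounds sit at the same place: the limit of > 100000 nM in this assay, at which 2 of the 2 values shown sit. Compound 3 `OC[C@@H](O)[C@H]1O[C@@H](n2cnc3c(-c4ccccc4)ncnc32)[C@H](O)[C@@H]1O` has phenyl in place of methylamino on an aromatic carbon. For the measured compounds named here, the one measured step that bears on this change is a step that the two limits leave unreadable from compound 1 to compound 2, and it offers no size to carry over. Going by the values given here, with that step as the only guide, a large gain in inhibition is not expected in this assay, and at most a small move toward stronger inhibition is anticipated. The estimated change is an at least 1.2-fold lower number from compound 2 to compound 3 (0.09 log units; that floor lies within the scatter). Compound 3 is expected at 80000 nM, with an estimated range of 20000 nM to 200000 nM.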

Compound 3, half-maximal inhibitory concentration: > 100000 nM
Compound 3 was reported as a limit; the forecaster's own chance of this, stated with the estimate: 65%; middle value at least 1.2-fold (0.09 log units) from the limit.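

In this assay, for the compounds shown here, compound 3 gives > 100000 nM as a limit, so no step among compound 1, compound 2 and compound 3 can be read. All three sit at one place: the limit of > 100000 nM in this assay, at which 3 of the 3 values shown sit.

The compounds shown leave open whether chloro, methylamino and phenyl differ at all in inhibition.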